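The source may hold more compounds than are shown below. What is called first, only, known or untested is meant among the compounds shown, and "the series" means these compounds.

Compound 3 `C#CCN(CCCCOc1ccc2ccc(=O)oc2c1)Cc1ccc(F)c(F)c1` gives the highest of the three numbers measured in an assay on isolated protein for inhibition of Amine oxidase [flavin-containing] B (Homo sapiens), read by fluorescence and Amplex Red, with stated times of 15 min and 20 min (a lower number here means a stronger inhibitor, a higher number a weaker inhibitor), at 2370 nM. Within the data shown here, compound 1 `C#CCN(CCCCOc1ccc2ccc(=O)oc2c1)Cc1ccc(C)cc1` gives 1680 nM, and the one measured step, a 1.4-fold higher number from compound 1 to compound 3 (0.15 log units; within the scatter), stays within the scatter. Compound 2 `C#CCN(C)CCCOc1ccc2ccc(=O)oc2c1`, which carries a methyl on the amine nitrogen and a shorter chain, gives 1090 nM. Compound 4 `C#CCN(C)CCCCOc1ccc2ccc(=O)oc2c1` differs from compound 3 by hydrogen in place of 3,4-difluorophenyl on a saturated chain carbon bound to an amine nitrogen. Among the measured compounds shown here, no measured step covers this change directly, and the single measured step concerns only the aryl group. The values of compound 2 and compound 3 show a lower number for the methyl compound, beyond the scatter. Compound 4 is therefore expected to show a step of a 2.4-fold lower number from compound 3 to compound 4 (0.37 log units; beyond the scatter). Compound 4 is estimated at 1000 nM, in a range from 400 nM to 2500 nM.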

Compound 4, half-maximal inhibitory concentration: 27 nM
The estimate for compound 4 lay 37-fold (1.57 log units) above the measured number; the whole stated range lies above it.
By their numbers in this assay, from the lowest: compound 4; then compounds 2, 1 and 3 (each within the scatter of the next, the first and the last beyond it).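

In this assay, hydrogen in place of 3,4-difluorophenyl gives an 88-fold lower number from compound 3 to compound 4 (1.94 log units; beyond the scatter) and hydrogen in place of 4-methylphenyl gives a 62-fold lower number from compound 1 to compound 4 (1.79 log units; beyond the scatter) on the same chain, so removing either aryl group matters far more here than exchanging one for the other. Among these compounds, with methyl on the amine nitrogen, the chain itself also counts: the longer chain gives a 40-fold lower number from compound 2 to compound 4 (1.61 log units; beyond the scatter) as a large step, a separate effect that the earlier compounds could not show. No measured evidence here accounts for these steps. The compounds shown leave open whether an ethyl group on the amine nitrogen, or a chain longer than that of compound 4, would keep this low number.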